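The source may report more compounds than this note shows. Statements on the series, on what has been measured and on what is new or still open speak of the compounds shown alone.

Compound 1 `O=C1O[C@H]([C@@H](O)Cn2cc(-c3cccc(O)c3)nn2)C(OCc2ccccc2)=C1OCc1ccccc1` is one of three compounds already tested in a functional assay on CFPAC-1 cells (Homo sapiens) for antiproliferative activity, read by MTT assay, with a stated time of 72 h (on this read-out lower numbers stand for stronger inhibition and higher numbers for weaker inhibition), where compound 1 gives 54100 nM. Compound 2 `O=C1O[C@H]([C@@H](O)Cn2cc(CNS(=O)(=O)c3ccc(F)cc3)nn2)C(OCc2ccccc2)=C1OCc1ccccc1` gives 34700 nM in this assay, and compound 3 `CC(C)(C)c1cn(C[C@H](O)[C@H]2OC(=O)C(OCc3ccccc3)=C2OCc2ccccc2)nn1` gives 54900 nM. The three numbers sit together within the usual scatter of the method: a 1.0-fold higher number from compound 1 to compound 3 (0.01 log units; within the scatter), a 1.6-fold lower number from compound 1 to compound 2 (0.19 log units; within the scatter) and a 1.6-fold higher number from compound 2 to compound 3 (0.20 log units; within the scatter). Compound 1 therefore stands neither apart from compound 3 nor from compound 2 in this assay.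

Compound 4 `Cc1ccc(S(=O)(=O)NCc2cn(C[C@H](O)[C@H]3OC(=O)C(OCc4ccccc4)=C3OCc3ccccc3)nn2)cc1` has not yet been measured. It differs from compound 1 in a single place: (((4-methylphenyl)sulfonyl)amino)methyl in place of 3-hydroxyphenyl on an aromatic carbon. Within the data shown here, the measured step that bears most directly on this change is the one from compound 1 to compound 2, which likewise put a sulfonylamino-methyl group in place of the 3-hydroxyphenyl, with the entering groups differing only in their 4-fluorophenyl or 4-methylphenyl part; that step was a 1.6-fold lower number from compound 1 to compound 2 (0.19 log units; within the scatter), within the scatter. The other steps, a 1.0-fold higher number from compound 1 to compound 3 (0.01 log units; within the scatter) and a 1.6-fold higher number from compound 2 to compound 3 (0.20 log units; within the scatter), also stayed within the scatter. Because a 1.6-fold lower number from compound 1 to compound 2 (0.19 log units; within the scatter) was small, compound 4 is expected to show no step beyond the scatter, a 1.4-fold lower number from compound 1 to compound 4 (0.15 log units; within the scatter). Compound 4 is accordingly estimated at 38000 nM, with a range from 20000 nM to 72000 nM.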

Compound 4, half-maximal inhibitory concentration: 68000 nM
Compound 4: the middle estimate sits 1.8-fold (0.25 log units) below what was measured; the measured number falls inside the stated range.
By their numbers in this assay, from the lowest: compounds 2, 1, 3 and 4 (each within the scatter of the next).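

In this assay, (((4-methylphenyl)sulfonyl)amino)methyl on the aromatic carbon of the five-membered ring with 3 nitrogen gives a 1.3-fold higher number from compound 1 to compound 4 (0.10 log units; within the scatter) when it takes the place of 3-hydroxyphenyl, and a 1.2-fold higher number from compound 3 to compound 4 (0.09 log units; within the scatter) when it takes the place of tert-butyl, so this larger group with 12 heavy atoms also produces no step beyond the scatter at this position. The compounds now also include a change within the sulfonyl group's aromatic ring: methyl in place of fluoro gives a 2.0-fold higher number from compound 2 to compound 4 (0.29 log units; within the scatter), which leaves the two sulfonylamino-methyl compounds within the scatter of each other. All four groups at this position therefore give numbers that cannot be separated in this read-out, and no available evidence accounts for that outcome.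

As far as these compounds go, it remains open whether an amine, a carboxylic acid or a longer chain on this aromatic carbon would produce a step beyond the scatter. From the compounds shown here alone, it also remains open whether a change elsewhere would move the number, as all four compounds share the core of compound 1 unchanged.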